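The source may report more compounds than this note shows. Statements on the series, on what has been measured and on what is new or still open speak of the compounds shown alone.

Measured compounds:
- compound 1 `CC1(C)OC(=O)C(=CNc2cccc(-c3nc4ccccc4s3)c2)C(=O)O1` — in an ADME assay on MT4 cells (Homo sapiens) for cytotoxicity, read by MTT assay, with a stated time of 4 days (a higher number here means that more compound is tolerated, a lower number that less compound is tolerated), compound 1 gives > 190000 nM
- compound 2 `O=c1cc[nH]c2c([N+](=O)[O-])cccc12` — in this assay compound 2 gives > 71600 nM

The value of compound 1 in this assay is a limit of the assay rather than a number, as the limit of > 190000 nM in this assay, at which 1 of the 2 values shown sits, records. The value of compound 2 in this assay is likewise a limit and not a number, as the limit of > 71600 nM in this assay, at which 1 of the 2 values shown sits, records. Within the data shown here, both measured compounds therefore stand at the tolerated edge of what the assay can report, and compound 1 stands there with no measured step to any other compound.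

Compound 3 `CC1(C)OC(=O)C(=CNc2cccc([N+](=O)[O-])c2)C(=O)O1` is the untested compound. It differs from compound 1 by nitro in place of 1,3-benzothiazol-2-yl on an aromatic carbon. Among the measured compounds shown here, no measured step of this kind is available, so no direction can be read from the data; since both measured values in this assay are limits, the step from compound 1 to compound 3 is expected to lie within the scatter, with the estimated change being a step that the limit leaves unreadable from compound 1 to compound 3. Compound 3 is accordingly expected to give about 200000 nM in this assay, in a range from 80000 nM to 500000 nM, most likely reported again as a limit.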

Compound 3, half-maximal cytotoxic concentration: > 251000 nM
Compound 3 gave a limit, no number; the forecaster's own chance of this, stated with the estimate: 75%; middle value at least 1.2-fold (0.09 log units) from the limit.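

Compound 3, like compound 1, ends at a limit of the assay in this assay and not at a number, so the step between compound 1 and compound 3 cannot be read. The compounds shown leave open at what concentration any of them becomes cytotoxic, and whether nitro in place of 1,3-benzothiazol-2-yl changes that concentration at all.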